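Replacing the amide substituent of compound 2 with an amino acid

The source may hold more compounds than are shown below. What is called first, only, known or untested is meant among the compounds shown, and "the series" means these compounds.

Compound 1 `CCn1c(C(=O)NCCN(C)C)ccc1C(CC)(CC)c1ccc(OCCC(O)(CC)CC)c(C)c1`: 870 nM
Compound 2 `C=CCN(C)C(=O)c1ccc(C(CC)(CC)c2ccc(OCCC(O)(CC)CC)c(C)c2)n1CC`: 12800 nM
Compound 3 `CCOc1ccc(NC(=O)c2ccc(C(CC)(CC)c3ccc(OCCC(O)(CC)CC)c(C)c3)n2CC)cc1`: > 50000 nM

In a functional assay on PC-3 cells (Homo sapiens) for antiproliferative activity, read by MTT assay, with a stated time of 48 h (on this read-out lower numbers stand for stronger inhibition and higher numbers for weaker inhibition), compound 1 gives the lowest number, and compound 2 stands highest of the two numbers shown, the step being a 15-fold higher number from compound 1 to compound 2 (1.17 log units; beyond the scatter). For compound 3 the assay reports only a limit, (the limit of > 50000 nM in this assay, at which 1 of the 3 values shown sits). Compound 4 `CCC(C)C(NC(=O)c1ccc(C(CC)(CC)c2ccc(OCCC(O)(CC)CC)c(C)c2)n1CC)C(=O)O` differs from compound 2 at the amide: (1-carboxy-2-methylbutyl)amino in place of allyl(methyl)amino on a carbonyl carbon. Among the compounds with values here, the steps that bear on this are an at least 3.9-fold higher number from compound 2 to compound 3 (0.59 log units; beyond the scatter) and an at least 57-fold higher number from compound 1 to compound 3 (1.75 log units; beyond the scatter), both large; each exchange of the amide substituent away from compound 1 has raised the number. Compound 4 is therefore expected to weaken further, with an estimated step of a 2.3-fold higher number from compound 2 to compound 4 (0.37 log units; beyond the scatter). Compound 4 is estimated at 30000 nM, in a range from 8000 nM to 100000 nM.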

Compound 4, half-maximal inhibitory concentration: 13800 nM
Beside the measured number, compound 4's estimate is 2.2-fold (0.34 log units) above it; the range from low to high includes it.
By their numbers in this assay, from the lowest: compound 1; then compounds 2 and 4 (each within the scatter of the next). At a limit, above all of these: compound 3.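

Exchanging allyl(methyl)amino for (1-carboxy-2-methylbutyl)amino on the carbonyl carbon leaves the reading in this assay level, with a 1.1-fold higher number from compound 2 to compound 4 (0.03 log units; within the scatter), so a carboxylic acid side chain can sit at this amide without a further rise. Against the other amides the same side chain gives an at least 3.6-fold lower number from compound 3 to compound 4 (0.55 log units; beyond the scatter) and a 16-fold higher number from compound 1 to compound 4 (1.20 log units; beyond the scatter), which leaves the 2-(dimethylamino)ethyl group of compound 1 alone at the low end. Compound 3 is only a limit: the limit of > 50000 nM in this assay, at which 1 of the 4 values shown sits.

As far as these compounds go, what remains open is whether the dimethylamino group or the length of its chain sets the number of compound 1. A primary amine on the same chain, a longer chain ending in dimethylamino, or the methyl ester of the acid in compound 4 could separate these.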